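The compounds below may be only part of what the source reports. "The series", "measured", "known", "first", "only" and "open" are said of these compounds alone.

Compound 1, `O=C(/C=C/c1ccc2c(c1)B(O)OC2)c1ccc(Br)cc1`: in an ADME assay on L929 cells (Mus musculus) for cytotoxicity, read by resazurin assay, with a stated time of 72 h (on this read-out higher numbers stand for weaker inhibition and lower numbers for stronger inhibition), compound 1 gives > 10 ug/mL, a limit of the assay.
Compound 2, `O=C(/C=C/c1ccc2c(c1)B(O)OC2)c1cccc(F)c1`: in this assay compound 2 gives > 10 ug/mL, again a limit.
Compound 3, `Nc1ccc(C(=O)/C=C/c2ccc3c(c2)B(O)OC3)cc1`: in this assay compound 3 gives > 10 ug/mL, also a limit.

Compound 2 therefore stands at the limit of > 10 ug/mL in this assay, at which 3 of the 3 values shown sit, and no number separates it from its neighbours. Compound 4, `COCOc1cccc(C(=O)/C=C/c2ccc3c(c2)B(O)OC3)c1`, differs from compound 2 by methoxymethoxy in place of fluoro on an aromatic carbon. On these data alone, the measured steps that touch this position are a step that the two limits leave unreadable from compound 1 to compound 2 and a step that the two limits leave unreadable from compound 2 to compound 3; both are hidden by limits, so their sizes are unknown and no direction can be drawn from them. On this evidence compound 4 is expected to sit at the same limit as compound 2, with an estimated 15 ug/mL and a range from 5 ug/mL to 50 ug/mL. The step this estimate means, a step that the limit leaves unreadable from compound 2 to compound 4, is expected to be none beyond the scatter.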

Compound 4, half-maximal inhibitory concentration: > 10 ug/mL
Compound 4: a limit, no number; the forecaster's own chance of this, stated with the estimate: 80%; the middle value is on the limit's open side.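

Within the data shown here, compound 2 and compound 4 both sit at a limit of the assay, so no step between them can be read. In this assay the compounds shown leave open where the half-maximal inhibitory concentration of each one actually lies.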